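A few compounds are considered here, and "the series" means these few. Any claim that something is new, unique, unknown or untested is made for them only; others in the source may bear on it.

Compound 1 `Nc1cc(N)c2nc(-c3ccccc3)c(Sc3ccc(F)cc3)nc2c1` is one of three compounds with a number in a functional assay on SK-MEL-5 cells (Homo sapiens) for inhibition, read by sulforhodamine B assay, with a stated time of 48 h; on this read-out lower numbers stand for stronger inhibition of growth and higher numbers for weaker inhibition of growth. Compound 1 gives 15500 nM there, the second highest of the three numbers. Its nearest neighbour is compound 3 `CCOC(=O)[C@H](CCC(=O)O)NC(=O)c1ccc(CNc2nc3cc(N)cc(N)c3nc2-c2ccccc2)cc1`, which gives 69200 nM in this assay, a higher number that lies beyond the scatter. Furthest from it is compound 2 `COc1cc(CNc2nc3cc(N)cc(N)c3nc2-c2ccccc2)cc(OC)c1OC`, which gives 724 nM in this assay, a lower number that also lies beyond the scatter.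

Among the compounds with values here, compound 4 `Nc1cc(N)c2nc(-c3ccccc3)c(NCc3ccc(F)cc3)nc2c1` has no measurement yet. It differs from compound 1 in a single place, ((4-fluorobenzyl)amino in place of (4-fluorophenyl)sulfanyl on an aromatic carbon), the (4-fluorobenzyl)amino group sitting on an aromatic carbon of the core next to the ring nitrogen.

Within the data shown here, no step between two measured compounds that differ in one place is available, so the expectation rests on the set as a whole. A change of this kind toward a benzylamino group is expected to bring a lower number, because compound 2, which also carries a benzylamino group on the same core, gives 724 nM in this assay. The estimated step of a 6.2-fold lower number from compound 1 to compound 4 (0.79 log units; beyond the scatter) is expected to exceed the scatter. Compound 4 is estimated to give 2500 nM in this assay, expected to fall between 600 nM and 10000 nM.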

Compound 4, concentration for 50% growth inhibition: 1860 nM
Compound 4: middle estimate off by 1.3-fold (0.13 log units), on the high side; the measured number falls inside the stated range.
By their numbers in this assay, from the lowest: compound 2; then compound 4; then compound 1; then compound 3.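

Within the data shown here, on the shared core, at the aromatic carbon next to the ring nitrogen, this is the first direct reading of a single change: in this assay, (4-fluorobenzyl)amino in place of (4-fluorophenyl)sulfanyl gives an 8.3-fold lower number from compound 1 to compound 4 (0.92 log units; beyond the scatter). Among these compounds, compounds 2 and 3 differ from compound 1 in more than one place, so only this pair shows that the number responds to the group at this position alone. Both groups carry a fluorinated six-membered aromatic ring of carbon, so the step reflects the link to that ring, but nothing measured here gives a reason for it.

Going by these compounds, it remains open how a longer chain between the core and the ring, or a simple amine at this position, would read. Also open, on these data alone, is how a benzylamino group with chlorine or methoxy in place of the fluorine would compare.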